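The source may report more compounds than this note shows. Statements on the series, on what has been measured and on what is new or still open speak of the compounds shown alone.

Series so far, in a functional assay on HeLa cells (Homo sapiens) for cytotoxicity, read by MTT assay, with stated times of 1 h, 15 min and 48 h; a higher number here means a weaker inhibitor, a lower number a stronger inhibitor:
- compound 1 `CC(C)(C)OC(=O)/C(C#N)=C/c1ccc(-c2ccc(-c3ccc(N(c4ccccc4)c4ccccc4)cc3)s2)s1`: > 100000 nM (a limit of the assay, not a number)
- compound 2 `N#C/C(=C\c1ccc(-c2ccc(-c3ccc(N(c4ccccc4)c4ccccc4)cc3)s2)s1)C(N)=O`: 8800 nM

Among the measured compounds shown here, compound 2 carries the only actual number. Compound 1 stands at a limit, (the limit of > 100000 nM in this assay, at which 1 of the 2 values shown sits).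

The next compound is compound 3 `O=Cc1ccc(-c2ccc(-c3ccc(N(c4ccccc4)c4ccccc4)cc3)s2)s1`. The change is formyl in place of 2-carbamoyl-2-cyanoethenyl on an aromatic carbon, next to the ring sulfur.

For the measured compounds named here, only one measured step bears on this, and only indirectly. That step, an at least 11-fold lower number from compound 1 to compound 2 (1.05 log units; beyond the scatter), is large and swaps amino for tert-butoxy on a carbonyl carbon, inside the group that compound 3 loses. Going by the values given here, no measured step removes the whole group, so the size of the change cannot be read directly. Compound 3 has no such amino group, so part of the gain seen in an at least 11-fold lower number from compound 1 to compound 2 (1.05 log units; beyond the scatter) is expected to be lost.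

The estimated move is a 2.8-fold higher number from compound 2 to compound 3 (0.45 log units; beyond the scatter), towards a higher number in this assay, and a reading at the limit is possible. For compound 3 the estimate is 25000 nM, with an expected range of 6000 nM to 100000 nM.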

Compound 3, half-maximal inhibitory concentration: 9500 nM
The estimate for compound 3 lay 2.6-fold (0.42 log units) above the measured number, and the stated range covers the measured number.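

In this assay, formyl in place of the whole 2-carbamoyl-2-cyanoethenyl on this aromatic carbon, next to the ring sulfur, gives a 1.1-fold higher number from compound 2 to compound 3 (0.03 log units; within the scatter), so the 7 heavy atoms of that group, with its hydrogen-bond donor and nitrile, are not needed for a reading of this size in this pair. The same formyl, set against 2-cyano-2-(tert-butoxycarbonyl)ethenyl, gives an at least 10-fold lower number from compound 1 to compound 3 (1.02 log units; beyond the scatter), which points to the tert-butoxycarbonyl-bearing group of compound 1 as the one that stands apart, rather than to the carbamoyl of compound 2 as a group that adds to the reading. The reading of compound 1 is a limit of the assay, not a number: the limit of > 100000 nM in this assay, at which 1 of the 3 values shown sits.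

Going by these compounds, what remains open is whether the separation of compound 1 belongs to the tert-butyl part alone or to any ester, which a methyl ester or a free carboxylic acid on the same ethenyl would test. On these data alone, it is also open whether this position tolerates groups other than carbonyl-bearing ones, such as a hydroxymethyl or an aminomethyl in place of formyl.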